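The source may report more compounds than this note shows. Statements on the series, on what has been measured and on what is new or still open speak of the compounds shown alone.

Of the compounds shown here, three built on one shared core have been tested in a functional assay on HT-29 cells (Homo sapiens) for cytotoxicity, read by MTT assay, with a stated time of 24 h, tested at 0.64 ug/mL; a higher number here means a stronger effect of the compound at the concentration tested, a lower number a weaker effect. Compound 1 `Cn1c(-c2ccc(NC(=O)CCl)cc2)nc(-c2ccccc2)c1-c1ccccc1` gives 7.2%. Compound 2 `Cn1c(-c2ccc(NC(=O)CSc3nc4ccccc4s3)cc2)nc(-c2ccccc2)c1-c1ccccc1` gives 9.8%, and compound 3 `Cc1nnc(SCC(=O)Nc2ccc(-c3nc(-c4ccccc4)c(-c4ccccc4)n3C)cc2)s1` gives 34.8%. Compound 2 thus stands second highest of the three numbers: the step of a number 2.6 percentage points higher from compound 1 to compound 2 (within the scatter) lies within the scatter, while the step of a number 25 percentage points higher from compound 2 to compound 3 (beyond the scatter) lies beyond it.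

Compound 4 `CN1CCN(CC(=O)Nc2ccc(-c3nc(-c4ccccc4)c(-c4ccccc4)n3C)cc2)CC1` has not yet been measured. Its difference from compound 2 is 4-methylpiperazin-1-yl in place of (1,3-benzothiazol-2-yl)sulfanyl on a saturated chain carbon bound to a carbonyl carbon. The measured steps at the same place are a number 2.6 percentage points higher from compound 1 to compound 2 (within the scatter) and a number 27.6 percentage points higher from compound 1 to compound 3 (beyond the scatter), and the exchange on the sulfur gives a number 25 percentage points higher from compound 2 to compound 3 (beyond the scatter), which shows that a change in this region can move the number modestly. None of these steps puts a 4-methylpiperazin-1-yl group in this place, so they offer no direct guide, only the observation that two of three groups tried here gave much the same number as the chloro starting point. The step of a number 2.2 percentage points higher from compound 2 to compound 4 (within the scatter) is therefore expected to stay within the scatter. Compound 4 is estimated at 12%, with a range from 3% to 30%.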

Compound 4, a percentage reported as activity, at one concentration (the size of the read-out at that concentration, not a potency): 18.8%
Compound 4: the middle estimate sits 6.8 percentage points below what was measured; measured number inside the range.
By their numbers in this assay, from the lowest: compounds 1, 2 and 4 (each within the scatter of the next, the first and the last beyond it); then compound 3.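

In this assay, 4-methylpiperazin-1-yl is the first group shown on this saturated chain carbon bound to a carbonyl carbon that contains no sulfur, and it still gives a change beyond the scatter from the chloro starting point: a number 11.6 percentage points higher from compound 1 to compound 4 (beyond the scatter). Sulfur is therefore not required for a change of this kind among these compounds, although (5-methyl-1,3,4-thiadiazol-2-yl)sulfanyl remains ahead of the new group, with a number 16 percentage points lower from compound 3 to compound 4 (beyond the scatter). Against (1,3-benzothiazol-2-yl)sulfanyl, the new group cannot be told apart, with a number 9 percentage points higher from compound 2 to compound 4 (within the scatter).

Nothing shown here gives a reason for these differences. Still open, from the compounds shown here alone, is how a morpholin-4-yl or a dimethylamino group would read at this place, and whether the same differences would hold at other concentrations.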